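The source may hold more compounds than are shown below. What is called first, only, known or untested is meant among the compounds shown, and "the series" means these compounds.

Measured in a physicochemical assay for solubility, in phosphate buffer, with a stated time of 24 h, at pH 7.4, tested at 100 uM; a lower number here means a less soluble compound, a higher number a more soluble compound:
- compound 1 `O=C(NCc1ccc(S(=O)(=O)c2ccccc2)cc1)N1CCc2ccncc2C1`: 115000 nM
- compound 2 `O=C(NCc1ccc(S(=O)(=O)C2CCOCC2)cc1)N1Cc2ccncc2C1`: 206000 nM

Compound 2, at 206000 nM, lies within the scatter of compound 1, at 115000 nM, so the two numbers do not separate these compounds in this assay. Among the measured compounds shown here, the two also differ in more than one place, and no measured pair isolates a single change.

The next compound, compound 3 `O=C(NCc1ccc(S(=O)(=O)N2CCOCC2)cc1)N1Cc2ccncc2C1`, is not yet measured. It departs from compound 2 in one place: morpholin-4-yl in place of oxan-4-yl on a sulfonyl sulfur. Morpholin-4-yl stands in place of oxan-4-yl on a sulfonyl sulfur, and both are six-membered non-aromatic rings with no net charge.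

For the measured compounds named here, with no measured precedent for this swap, the expectation starts from compound 2 at 206000 nM, with no clear direction. The estimated 1.2-fold lower number from compound 2 to compound 3 (0.08 log units; within the scatter) is small and within the scatter. For compound 3 the expected value is 170000 nM, with an estimated range of 90000 nM to 320000 nM.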

Compound 3, solubility: 59000 nM
Estimate against measurement, compound 3: 2.9-fold (0.46 log units) above; measured number outside the range, below it.
By their numbers in this assay, from the lowest: compounds 3, 1 and 2 (each within the scatter of the next, the first and the last beyond it).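

Among the compounds shown here, on the sulfonyl sulfur whose other neighbour is an aromatic carbon, morpholin-4-yl in place of oxan-4-yl gives the first single-place comparison of the series: in this assay, the result is a 3.5-fold lower number from compound 2 to compound 3 (0.54 log units; beyond the scatter). Both groups are six-membered non-aromatic rings with no net charge, so this position distinguishes two rings that ring size and charge do not separate. Nothing available explains the step.

As far as these compounds go, it remains open whether piperidin-1-yl or a dimethylamino group on the same sulfonyl sulfur would give a number closer to that of compound 2 or compound 3. From the compounds shown here alone, it is also open whether the same exchange gives a step of similar size on the core of compound 1, since that compound differs from the other two in more than one place.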